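The source may report more compounds than this note shows. Statements on the series, on what has been measured and on what is new or still open speak of the compounds shown alone.

Of the compounds shown here, three sharing one core have been measured in an assay on isolated protein for inhibition of Nicotinamide phosphoribosyltransferase (Homo sapiens), read by WST assay, with stated times of 60 min, 5 min and 30 min, in the presence of a further agent that is not named here; a higher number here means a weaker inhibitor, a lower number a stronger inhibitor. Compound 1 `Cc1ccc(NS(=O)(=O)c2cccc(CCCCCCNC(=O)/C=C/c3cccnc3)c2)cc1` gives 9.78 nM. Compound 2 `Cc1ccc(C)c(NS(=O)(=O)c2cccc(CCCCCCNC(=O)/C=C/c3cccnc3)c2)c1` gives 11.6 nM. Compound 3 `O=C(/C=C/c1cccnc1)NCCCCCCc1cccc(S(=O)(=O)Nc2ccc(F)cc2)c1` gives 9.2 nM. Compound 3 thus carries the lowest of the three numbers, but its step to compound 1 and its step to compound 2 both lie within the scatter, so no order among the three can be read from these values.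

Compound 4 `O=C(/C=C/c1cccnc1)NCCCCCCc1cccc(S(=O)(=O)Nc2ccc(C(F)(F)F)cc2)c1` differs from compound 3 by one change: trifluoromethyl in place of fluoro on an aromatic carbon. Among the compounds with values here, every measured step so far also concerns the group on the sulfonamide nitrogen. The step of a 1.2-fold higher number from compound 1 to compound 2 (0.07 log units; within the scatter), the step of a 1.1-fold lower number from compound 1 to compound 3 (0.03 log units; within the scatter) and the step of a 1.3-fold lower number from compound 2 to compound 3 (0.10 log units; within the scatter) all stayed within the scatter, whether a methyl was exchanged for a fluoro or one methylated ring for another. Nothing seen here suggests that the position para to the large group is sensitive to what sits on it. The expected step from compound 3 to compound 4 in this assay is therefore a 1.2-fold higher number from compound 3 to compound 4 (0.08 log units; within the scatter), with no direction that can be called beyond the scatter. For compound 4 the estimate in this assay is 11 nM, with a likely range from 4.5 nM to 27 nM.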

Compound 4, half-maximal inhibitory concentration: 24.5 nM
Compound 4: middle estimate off by 2.2-fold (0.35 log units), on the low side; the range from low to high includes it.
By their numbers in this assay, from the lowest: compounds 3, 1 and 2 (each within the scatter of the next); then compound 4.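

Among the groups shown on an aromatic carbon para to a large group, trifluoromethyl alone moves the number beyond the scatter in this assay: it gives a 2.7-fold higher number from compound 3 to compound 4 (0.43 log units; beyond the scatter) and points the same way with a 2.5-fold higher number from compound 1 to compound 4 (0.40 log units; beyond the scatter) and with a 2.1-fold higher number from compound 2 to compound 4 (0.32 log units; beyond the scatter) in the comparisons with the other two compounds. This place is therefore not indifferent to what sits on it, since compound 1 with methyl and compound 3 with fluoro stand within the scatter of each other, while trifluoromethyl, with its 4 heavy atoms against the 1 of fluoro, gives a weaker inhibitor, though only modestly so. Nothing given here bears on why this exchange raises the number.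

Going by these compounds, whether a chloro, a methoxy, a nitrile or a carboxylic acid at this same place would stand with fluoro and methyl or with trifluoromethyl remains open. Also open, on these data alone, is whether the exchange of fluoro for trifluoromethyl would give a step of similar size on a core with a shorter chain or with a different group in place of the amide.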